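Swapping a propyl for a cyclopentyl on an amide nitrogen

The source may report more compounds than this note shows. Statements on the series, on what has been measured and on what is new or still open speak of the compounds shown alone.

Measured compounds:
- compound 1, `COc1cc2c(cc1OC)C(CC(=O)N(C)C)CC2`: 33.3%
- compound 2, `CCCNC(=O)CC1CCc2cc(OC)c(OC)cc21`: 22.2%

Both compounds share one core and differ only in the group on the carbonyl carbon. In a functional assay on the whole organism (strain Wistar) for inhibition, with Rattus norvegicus as the target, read by paw edema, with stated times of 60 min and 6 h, at a dose of 100 mg/kg by the oral route (on this read-out lower numbers stand for less inhibition and higher numbers for more inhibition at the one dose given (going by the name of the read-out)), compound 1 gives 33.3%. Compound 2 stands at the bottom of these two numbers, with a number 11.1 percentage points lower from compound 1 to compound 2 (beyond the scatter), a modest step, through propylamino in place of dimethylamino on a carbonyl carbon.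

The next compound, compound 3, `COc1cc2c(cc1OC)C(CC(=O)NC1CCCC1)CC2`, keeps everything of compound 2 except the group on the amide-type nitrogen, whose other neighbour is the carbonyl carbon: cyclopentyl in place of propyl on an amide-type nitrogen. Going by the values given here, the measured step between compound 1 and compound 2 concerns a different exchange on the same nitrogen, so no step in hand speaks to this particular change. Among the compounds with values here, compound 2 is therefore the only guide, and little movement beyond the scatter is expected: an estimated a number 0.2 percentage points lower from compound 2 to compound 3 (within the scatter). Compound 3 is thus expected to show roughly 22%, within a range of 8% to 38%, in this assay.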

Compound 3, a percentage reported as inhibition, in the whole organism at one dose (the size of the read-out at that dose, not a potency): 40.7%
The estimate for compound 3 lay 18.7 percentage points below the measured number; measured number above the stated range.
By their numbers in this assay, from the lowest: compound 2; then compounds 1 and 3 (each within the scatter of the next).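

Going by these compounds alone, the group on this amide-type nitrogen matters more than the earlier compounds could show: in this assay, cyclopentyl in place of propyl gives a number 18.5 percentage points higher from compound 2 to compound 3 (beyond the scatter). The low number of compound 2 therefore does not follow simply from the nitrogen carrying one group and keeping the amide hydrogen, since compound 3 has that same arrangement. Exchanging dimethylamino for cyclopentylamino gives a number 7.4 percentage points higher from compound 1 to compound 3 (within the scatter), so these two quite different amides cannot be told apart at this one dose, and no explanation for the rise from propyl to cyclopentyl is available from any supporting data.

This pair changes two things together, the ring and the carbon count, so it cannot say which of them goes with the higher number; pentyl, an open chain with the same carbon count as cyclopentyl, would separate the two. Cyclobutyl and cyclohexyl would show whether ring size matters at this nitrogen, and a phenyl ring would show whether a non-aromatic ring is needed.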